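A few compounds are considered here, and "the series" means these few. Any claim that something is new, unique, unknown or untested is made for them only; others in the source may bear on it.

Compounds measured in an assay on isolated protein for binding affinity to adenosine receptor A1 (Bos taurus); on this read-out higher numbers stand for weaker inhibition and lower numbers for stronger inhibition:
compound 1 `COc1ccc(C(=O)Nc2nc(-c3ccccc3)nc3c2nnn3Cc2ccccc2F)cc1` gives 21900000 nM
compound 2 `OCCCNc1nc(-c2ccccc2)nc2c1nnn2Cc1ccccc1F` gives 3700000 nM
compound 3 `CCCNc1nc(-c2ccccc2)nc2c1nnn2Cc1ccccc1F` gives 3200000 nM

Compound 3 holds the lowest number of the three in this assay. The step of a 1.2-fold lower number from compound 2 to compound 3 (0.06 log units; within the scatter) lies within the scatter, so compound 3 and compound 2 cannot be told apart on these numbers. Compound 1 is set off from both: a 6.8-fold lower number from compound 1 to compound 3 (0.84 log units; beyond the scatter) and a 5.9-fold lower number from compound 1 to compound 2 (0.77 log units; beyond the scatter) are beyond the scatter, and both come from exchanging the (4-methoxyphenyl)carbonyl on the nitrogen on the aromatic ring for a short saturated chain.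

Compound 4 `CCCCCCNc1nc(-c2ccccc2)nc2c1nnn2Cc1ccccc1F` differs from compound 3 by propyl in place of hydrogen on a saturated chain carbon, three bonds along the chain from a nitrogen on an aromatic ring. Going by the values given here, no measured step bears directly on this change: the two steps from compound 1 swap the whole group on the aromatic nitrogen, and the step from compound 2 to compound 3 only removes a hydroxy from the chain, staying within the scatter. Among the chain-bearing compounds the numbers hardly move, so lengthening the chain is expected to bring no step beyond the scatter, a 1.3-fold lower number from compound 3 to compound 4 (0.11 log units; within the scatter), with a wide range on either side. Compound 4 is therefore estimated at 2500000 nM in this assay, between 600000 nM and 10000000 nM.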

Compound 4, inhibition constant: 25000000 nM
For compound 4 the middle estimate is 10-fold (1.00 log units) below the measured one; measured number above the stated range.
By their numbers in this assay, from the lowest: compounds 3 and 2 (each within the scatter of the next); then compounds 1 and 4 (each within the scatter of the next).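

In this assay the saturated chain on the nitrogen on the aromatic ring proves sensitive to length: propyl to hexyl gives a 7.8-fold higher number from compound 3 to compound 4 (0.89 log units; beyond the scatter) and so ends the flat picture seen among the shorter chains. Propyl in place of hydroxy at the same place gives a step of similar size, a 6.8-fold higher number from compound 2 to compound 4 (0.83 log units; beyond the scatter) and this places hexyl apart from both shorter chains, with or without the hydroxy. The lower number that came with replacing (4-methoxyphenyl)carbonyl by a saturated chain is therefore not shared by every such chain, since a 1.1-fold higher number from compound 1 to compound 4 (0.06 log units; within the scatter) leaves hexyl and that group indistinguishable; no accompanying data account for the higher number with hexyl.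

The compounds shown leave open where between propyl and hexyl the number starts to climb, as a butyl or pentyl chain would show, and whether a still longer chain such as octyl continues the trend. Also open, going by these compounds, is whether an amine or a carboxylic acid in place of the hydroxy of compound 2 would stay within the scatter of compound 3, and what a hydroxy would do on the hexyl chain of compound 4.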